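A few compounds are considered here, and "the series" means these few. Any claim that something is new, unique, unknown or untested is made for them only; others in the source may bear on it.

Of the compounds shown here, three that share one core have been tested in a functional assay on HL-60 cells (Homo sapiens) for inhibition, read by MTT assay, with a stated time of 72 h; a higher number here means a weaker inhibitor, a lower number a stronger inhibitor. Compound 1 `Cc1nc(-c2ccccc2)c(C(=O)N2CCN(c3ccc(C(F)(F)F)cc3)CC2)o1` carries a 4-(trifluoromethyl)phenyl on the amine nitrogen in a ring. In this assay compound 1 gives a limit rather than a number, > 1000 nM (the limit of > 1000 nM in this assay, at which 1 of the 3 values shown sits). Compound 2 `CCOc1cccc(N2CCN(C(=O)c3oc(C)nc3-c3ccccc3)CC2)c1` carries a 3-ethoxyphenyl on that nitrogen, and in this assay compound 2 gives 151 nM. Within the data shown here, compound 3 `Cc1cc(C)cc(N2CCN(C(=O)c3oc(C)nc3-c3ccccc3)CC2)c1` carries a 3,5-dimethylphenyl there, and in this assay compound 3 gives 34.5 nM, the lowest of the two numbers so far. The measured steps were an at least 6.6-fold lower number from compound 1 to compound 2 (0.82 log units; beyond the scatter), an at least 28-fold lower number from compound 1 to compound 3 (1.46 log units; beyond the scatter) and a 4.4-fold lower number from compound 2 to compound 3 (0.64 log units; beyond the scatter).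

Compound 4 `COc1cc(OC)cc(N2CCN(C(=O)c3oc(C)nc3-c3ccccc3)CC2)c1` has not yet been measured. It differs from compound 3 in one place: 3,5-dimethoxyphenyl in place of 3,5-dimethylphenyl on an amine nitrogen in a ring. The step that speaks to this change is a 4.4-fold lower number from compound 2 to compound 3 (0.64 log units; beyond the scatter), where the phenyl bearing an oxygen-linked ethyl gave the higher number and the dimethylphenyl the lower one. Compound 4 keeps the pattern of two groups on the phenyl but swaps each methyl for a methoxy, so a modest rise in the number is expected, smaller than that step since the substitution pattern of compound 3 is kept. Compound 4 is therefore expected to give about 100 nM in this assay, with a likely range from 35 nM to 300 nM. That estimate means an expected step of a 2.9-fold higher number from compound 3 to compound 4 (0.46 log units; beyond the scatter).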

Compound 4, half-maximal inhibitory concentration: 19.2 nM
Compound 4: middle estimate off by 5.2-fold (0.72 log units), on the high side; measured number below the stated range.
By their numbers in this assay, from the lowest: compounds 4 and 3 (each within the scatter of the next); then compound 2. At a limit, above all of these: compound 1.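

In this assay, the 3,5-dimethoxyphenyl and the 3,5-dimethylphenyl on the amine nitrogen in a ring cannot be told apart, with a 1.8-fold lower number from compound 3 to compound 4 (0.25 log units; within the scatter), so swapping these carbon-linked methyl groups for oxygen-linked methoxy groups makes no measurable difference here. Oxygen-linked groups on this phenyl therefore do not by themselves bring the higher number seen with the 3-ethoxyphenyl, as the comparison with the 3,5-dimethoxyphenyl shows: a 7.9-fold lower number from compound 2 to compound 4 (0.90 log units; beyond the scatter). The largest step reaches back to the 4-(trifluoromethyl)phenyl, an at least 52-fold lower number from compound 1 to compound 4 (1.71 log units; beyond the scatter), but its true size stays unknown because compound 1 stands at a limit: the limit of > 1000 nM in this assay, at which 1 of the 4 values shown sits.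

From the compounds shown here alone, what remains open is whether the gap between compound 2 and compound 4 comes from the second group on the phenyl or from ethoxy versus methoxy; a 3-methoxyphenyl and a 3,5-diethoxyphenyl would separate these two readings. Going by these compounds, it is also open how far this tolerance extends, for instance to a 3,5-dichlorophenyl or to a phenyl carrying an amine or a carboxylic acid at these places.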